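The source may report more compounds than this note shows. Statements on the series, on what has been measured and on what is new or still open speak of the compounds shown alone.

Measured so far:
- compound 1 `Cc1noc(C)c1-c1cnc(N)c(Oc2ccc(C(=O)Nc3ccc(Cl)cn3)cc2)n1`: 9180 nM
- compound 2 `Cn1cc(-c2cnc(N)c(Oc3ccc(C(=O)Nc4ccc(Cl)cc4)cc3)n2)cn1`: 3080 nM
- compound 3 `Cn1cc(-c2cnc(N)c(Oc3ccc(C(=O)Nc4cccc(Cl)c4)cc3)n2)cn1`: 24500 nM

In a functional assay on LoVo cells (Homo sapiens) for inhibition, read by MTT assay, with a stated time of 72 h (on this read-out higher numbers stand for weaker inhibition and lower numbers for stronger inhibition), compound 3 gives 24500 nM, the highest of the three numbers; compound 1 sits nearest to it and compound 2 furthest. For the measured compounds named here, the step of an 8.0-fold higher number from compound 2 to compound 3 (0.90 log units; beyond the scatter) is the only one between compounds that differ in a single place, and it is the one that bears on what follows.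

Compound 4 `Cn1cc(-c2cnc(N)c(Oc3ccc(C(=O)Nc4ccc(Cl)cn4)cc3)n2)cn1` differs from compound 3 in one place: 5-chloropyridin-2-yl in place of 3-chlorophenyl on an amide-type nitrogen. Going by the values given here, the group that enters is the same one that compound 3 carries in compound 1, which in this assay gives 9180 nM on a different core; compound 1 and compound 4 differ in two places, so no step between them can be written. Compound 4 is also compound 2 with the ring nitrogen added, and compound 2 gives 3080 nM. Since an 8.0-fold higher number from compound 2 to compound 3 (0.90 log units; beyond the scatter) shows the 3-chloro arrangement weakening inhibition, undoing it is expected to lower the number for compound 4 by a 4.9-fold lower number from compound 3 to compound 4 (0.69 log units; beyond the scatter). The estimate for compound 4 is therefore 5000 nM, within a range of 1500 nM to 16000 nM.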

Compound 4, half-maximal inhibitory concentration: 6160 nM
Estimate against measurement, compound 4: 1.2-fold (0.09 log units) below; measured number inside the range.
By their numbers in this assay, from the lowest: compounds 2, 4 and 1 (each within the scatter of the next, the first and the last beyond it); then compound 3.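

In this assay, the change at the amide-type nitrogen gives a 4.0-fold lower number from compound 3 to compound 4 (0.60 log units; beyond the scatter), so 5-chloropyridin-2-yl clearly separates from 3-chlorophenyl at this place. The comparison with the other chlorinated group gives a 2.0-fold higher number from compound 2 to compound 4 (0.30 log units; within the scatter), which means that 5-chloropyridin-2-yl and 4-chlorophenyl cannot be told apart here, even though the entering group counts one hydrogen-bond acceptor and 4-chlorophenyl, as an aryl group of carbon only, has no ring hetero atom. With 5-chloropyridin-2-yl held on the amide-type nitrogen, the change on the aromatic carbon gives a 1.5-fold lower number from compound 1 to compound 4 (0.17 log units; within the scatter), so 1-methyl-1H-pyrazol-4-yl and 3,5-dimethyl-1,2-oxazol-4-yl are likewise not separated in this pair.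

No measurement available here accounts for the separation of 3-chlorophenyl from the other two groups at the amide-type nitrogen. The compounds shown also leave open whether a methoxy group or a nitrile in place of the chlorine of 5-chloropyridin-2-yl, or a morpholine ring in place of 1-methyl-1H-pyrazol-4-yl on the aromatic carbon, would move the number beyond the scatter.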